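The compounds below may be only part of what the source reports. "The series", "measured", "known", "first", "only" and "open" are said of these compounds alone.

Measured compounds:
compound 1 `CCC(CC)C1C(C(=O)c2ccc(OC)cc2)=C(O)C(=O)N1c1ccc(-c2ccon2)cc1` — in an ADME assay on the whole organism (Rattus norvegicus) for pharmacokinetics, at a dose of 1 mg/kg by the oral route (on this read-out higher numbers stand for higher oral bioavailability and lower numbers for lower oral bioavailability), compound 1 gives 18.9%
compound 2 `COc1ccc(C(=O)C2=C(O)C(=O)N(c3ccc(-c4ccon4)cc3)C2c2ccccc2OC)cc1` — in this assay compound 2 gives 19.9%

Compound 2 holds the higher of the two numbers in this assay, but only by a number 1 percentage points higher from compound 1 to compound 2 (within the scatter), so the two values do not separate. That single measured step exchanges the group on a saturated ring carbon of the shared core and gives no information about the methoxy group on the 2-methoxyphenyl of compound 2.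

Compound 3, `COc1ccc(C(=O)C2=C(O)C(=O)N(c3ccc(-c4ccon4)cc3)C2c2ccccc2OCCO)cc1`, differs from compound 2 by hydroxymethyl in place of hydrogen on a saturated chain carbon bound to an oxygen on an aromatic ring; the same difference, cut one bond further out, reads methoxy to 2-hydroxyethoxy. Within the data shown here, no measured pair carries this change, and the only step available was within the scatter. Among the measured compounds shown here, with no bearing step, nothing points to a move beyond the scatter in this assay in either direction; the expected step is therefore about a number 2.9 percentage points lower from compound 2 to compound 3 (within the scatter), that is, none beyond the scatter. For compound 3 the estimate in this assay is 17%, within 7% to 30%.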

Compound 3, oral bioavailability: 9%
Compound 3: middle estimate off by 8 percentage points, on the high side; low and high end bracket the measured number.
By their numbers in this assay, from the lowest: compounds 3, 1 and 2 (each within the scatter of the next, the first and the last beyond it).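

In this assay, among these compounds, the change of methoxy to 2-hydroxyethoxy gives a number 10.9 percentage points lower from compound 2 to compound 3 (beyond the scatter) and is the first step to pass the scatter, so this read-out does respond to the group on the oxygen of the aromatic ring, which the earlier exchange on the saturated ring carbon could not show. Among the compounds shown here, measured against the pentan-3-yl of compound 1, the 2-(2-hydroxyethoxy)phenyl gives a number 9.9 percentage points lower from compound 1 to compound 3 (within the scatter) and does not separate, so the modest drop rests on the single comparison with compound 2. No measured evidence is available to explain either step.

The compounds shown leave open whether the drop belongs to the hydroxyl of the 2-hydroxyethoxy group or to the longer chain itself, a question that an ethoxy or a 2-methoxyethoxy group on the same oxygen would address. They also leave open how this read-out responds to a 2-aminoethoxy or a carboxymethoxy group there, and whether the same change behaves alike on other groups at the saturated ring carbon.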